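Compound 3 to compound 4: cyclopropyl in place of ethyl

A few compounds are considered here, and "the series" means these few. Any claim that something is new, unique, unknown or untested is made for them only; others in the source may bear on it.

For the measured compounds named here, the series so far holds compound 1 (`COc1cc(C(=O)N2CCCC2)cc2nc(NCc3cccc(Cl)c3)oc12`), compound 2 (`COc1cc(C(=O)N2CC[C@@H](O)[C@H](C)C2)cc2nc(NCc3cccc(Cl)c3)oc12`) and compound 3 (`CCC1CC(O)C(C)CN1C(=O)c1cc(OC)c2oc(NCc3cccc(Cl)c3)nc2c1`) on a shared core. In an ADME assay on Caco-2 cells (Homo sapiens) for permeability, read by LC-MS, in the apical to basolateral direction, with a stated time of 2 h (a lower number here means that the compound crosses the layer more slowly, a higher number that the compound crosses the layer faster), compound 1 gives "not determined" (no result reported) and compound 2 gives 126 nm/s. Compound 3 stands at "not determined" (no result reported), so the step starts from no measured number. Compound 4 (`COc1cc(C(=O)N2CC(C)C(O)CC2C2CC2)cc2nc(NCc3cccc(Cl)c3)oc12`) has cyclopropyl in place of ethyl on a saturated ring carbon, next to the ring nitrogen: cyclopropyl in place of ethyl on a saturated ring carbon. In this assay, going by the values given here, no step beyond the usual scatter is expected from this change, in either direction, although no measured pair tests it. Among the compounds with values here, the only anchor is compound 2 at 126 nm/s, which carries neither group. Compound 4 is expected at 140 nm/s, with an estimated range of 50 nm/s to 350 nm/s.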

Compound 4, apparent permeability: 138 nm/s
Beside the measured number, compound 4's estimate is 1.0-fold (0.01 log units) above it; the range from low to high includes it.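

Against 4-hydroxy-3-methylpiperidin-1-yl, the 2-cyclopropyl-4-hydroxy-5-methylpiperidin-1-yl group on the carbonyl carbon gives a 1.1-fold higher number from compound 2 to compound 4 (0.04 log units; within the scatter) in this assay. A cyclopropyl on this saturated ring carbon, next to the ring nitrogen, therefore comes with no step beyond the scatter in the compounds shown. Compound 3 has no number, so the step from ethyl to cyclopropyl cannot be read.

On these data alone, whether an amine or a longer chain such as n-butyl on this ring carbon would also stay within the scatter remains open. No measurement at hand offers an explanation for this result.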